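The source may hold more compounds than are shown below. What is called first, only, known or untested is meant among the compounds shown, and "the series" means these compounds.

Compound 1 `Cc1cccc(-n2nncc2CN2C(=O)C3(C(C#N)=C(N)Oc4c(N)cc5nc6ccccc6nc5c43)c3ccccc32)c1`: > 50000 nM
Compound 2 `N#CC1=C(N)Oc2c(N)cc3nc4ccccc4nc3c2C12C(=O)N(Cc1cnnn1-c1ccc(Cl)cc1)c1ccccc12`: > 50000 nM
Compound 3 `N#CC1=C(N)Oc2c(N)cc3nc4ccccc4nc3c2C12C(=O)N(Cc1cnnn1-c1ccc(F)c(Cl)c1)c1ccccc12`: > 50000 nM

Of the compounds shown here, three have been tested in an ADME assay on HUVEC cells (Homo sapiens) for antiproliferative activity, read by MTT assay, with a stated time of 48 h (on this read-out higher numbers stand for weaker inhibition and lower numbers for stronger inhibition), and none returned a number. Compound 1 sits only at a limit of this assay, > 50000 nM. Compound 2 likewise is known only as a limit, > 50000 nM. Compound 3, the starting point of the step that follows, is known only as a limit as well, > 50000 nM. All three therefore rest on (the limit of > 50000 nM in this assay, at which 3 of the 3 values shown sit), and compound 3 cannot be placed above or below its two neighbours on the numbers shown.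

The steps among them are accordingly silent: a step that the two limits leave unreadable from compound 1 to compound 2, a step that the two limits leave unreadable from compound 1 to compound 3 and a step that the two limits leave unreadable from compound 2 to compound 3. Each of these changes the aryl group on the triazole nitrogen without lifting any compound off the limit.

Compound 4 `COc1cc(-n2nncc2CN2C(=O)C3(C(C#N)=C(N)Oc4c(N)cc5nc6ccccc6nc5c43)c3ccccc32)c(OC)cc1Cl` differs from compound 3 in the same position: 4-chloro-2,5-dimethoxyphenyl in place of 3-chloro-4-fluorophenyl on an aromatic nitrogen. Since every measured step at this position has been unreadable, no direction and no size can be read for the move from compound 3 to compound 4; the only expectation the data support is that compound 4 stays where all three measured compounds sit. Compound 4 is therefore estimated in this assay at 100000 nM, within 30000 nM to 400000 nM, which as a step means an expected step that the limit leaves unreadable from compound 3 to compound 4.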

Compound 4, half-maximal inhibitory concentration: > 50000 nM
Compound 4: only a limit was reported; the forecaster's own chance of this, stated with the estimate: 85%; the middle value is on the limit's open side.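

Compound 4 is likewise known only as a limit in this assay, namely > 50000 nM. Its steps from compound 1, compound 2 and compound 3 therefore cannot be read, and the picture stays as it was: the limit of > 50000 nM in this assay, at which 4 of the 4 values shown sit. The compounds shown leave open whether any aryl group on the aromatic nitrogen gives a measurable value in this assay.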